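Swapping 3-methylphenyl for thiophen-2-yl

The source may hold more compounds than are shown below. What is called first, only, known or untested is meant among the compounds shown, and "the series" means these compounds.

In a functional assay on U-251 cells (Homo sapiens) for antiproliferative activity, read by MTT assay, with a stated time of 48 h (on this read-out lower numbers stand for stronger inhibition and higher numbers for weaker inhibition), compound 1 `COc1ccc(-c2nc3cccc(-c4cc(OC)c(OC)c(OC)c4)c3o2)cc1OC` gives 1300 nM and compound 2 `COc1cc(-c2cccc3nc(-c4cccc(F)c4)oc23)cc(OC)c1OC` gives 2900 nM. Compound 3 `COc1cc(-c2cccc3nc(-c4cccc(C)c4)oc23)cc(OC)c1OC` reads > 25000 nM, which is a limit of the assay and not a number, and this puts it at the weak end of the three. Compound 4 `COc1cc(-c2cccc3nc(-c4cccs4)oc23)cc(OC)c1OC` carries thiophen-2-yl in place of 3-methylphenyl on an aromatic carbon. Changes at this same place have already mattered: an at least 19-fold higher number from compound 1 to compound 3 (1.28 log units; beyond the scatter) was large, an at least 8.6-fold higher number from compound 2 to compound 3 (0.93 log units; beyond the scatter) was at least modest, and a 2.2-fold higher number from compound 1 to compound 2 (0.35 log units; beyond the scatter) was modest. Leaving 3-methylphenyl may therefore restore some activity, as the value of compound 2 at 2900 nM suggests. The expected change, toward stronger inhibition, is an at least 4.1-fold lower number from compound 3 to compound 4 (0.61 log units; beyond the scatter). For compound 4 the estimate is 6000 nM, with an expected range of 1500 nM to 25000 nM.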

Compound 4, half-maximal inhibitory concentration: 3000 nM
Beside the measured number, compound 4's estimate is 2.0-fold (0.30 log units) above it; the range from low to high includes it.
By their numbers in this assay, from the lowest: compound 1; then compounds 2 and 4 (each within the scatter of the next). At a limit, above all of these: compound 3.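

Thiophen-2-yl gives an at least 8.3-fold lower number from compound 3 to compound 4 (0.92 log units; beyond the scatter), so at this position, in this assay, the loss seen with 3-methylphenyl does not extend to this five-membered ring. Going by these compounds, compound 3 reads as a limit of the assay and not a number, so the true size of that step stays unknown: the limit of > 25000 nM in this assay, at which 1 of the 4 values shown sits. Thiophen-2-yl and 3-fluorophenyl cannot be told apart, with a 1.0-fold higher number from compound 2 to compound 4 (0.01 log units; within the scatter), while 3,4-dimethoxyphenyl keeps a modest edge, with a 2.3-fold higher number from compound 1 to compound 4 (0.36 log units; beyond the scatter).

The compounds shown leave open how furan-2-yl or a phenyl carrying a carboxylic acid would read at this position. They also leave open why methyl in place of fluoro costs so much.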